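The source may report more compounds than this note shows. Statements on the series, on what has been measured and on what is new or still open speak of the compounds shown alone.

Compound 1 `CNC(=O)/C=C1\CCc2cc(F)c(F)cc21` and compound 2 `NC(=O)/C=C1\CCc2cc(F)c(F)cc21` share one core, while compound 3 `CCCNC(=O)/C=C1\CCc2ccc(F)cc21` and the still unmeasured compound 4 `CN(C)C(=O)/C=C1\CCc2ccc(F)cc21` share another. In a functional assay on the whole organism with Mus musculus as the target (on this read-out lower numbers stand for an effect already at smaller amounts and higher numbers for an effect only at larger amounts of compound), compound 1 gives 96 mg/kg, and compound 2 gives 64 mg/kg. The step of a 1.5-fold lower number from compound 1 to compound 2 (0.18 log units; within the scatter) lies within the scatter, so these two values are read as alike. For compound 3 the assay reports only a limit, > 100 mg/kg. Compound 3 thus sits at the limit of > 100 mg/kg in this assay, at which 1 of the 3 values shown sits, and no exact number is known for it. The change from compound 3 to compound 4 is dimethylamino in place of propylamino on a carbonyl carbon. Within the data shown here, only one measured step touches the same part of the molecule, the amide-type nitrogen: the one from compound 1 to compound 2, which stayed within the scatter. That step, however, replaces a methyl with a hydrogen rather than a propylamino with a dimethylamino, and it was measured on the other core. The measured steps therefore give little basis for expecting a shift beyond the scatter in this assay, and as compound 3 offers only a limit, the most likely outcome is that compound 4 also sits at or near that limit. Compound 4 is expected to give about 120 mg/kg, between 60 mg/kg and 250 mg/kg, an estimated step that the limit leaves unreadable from compound 3 to compound 4.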

Compound 4, dose for half-maximal effect: > 100 mg/kg
Compound 4: a limit, no number; the forecaster's own chance of this, stated with the estimate: 60%; the middle value does not contradict the limit.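

In this assay compound 4 gives > 100 mg/kg, which is a limit and not a number. Compound 3 is also reported only as a limit, so no step from compound 3 to compound 4 can be read: the limit of > 100 mg/kg in this assay, at which 2 of the 4 values shown sit.

The compounds shown leave open whether dimethylamino in place of propylamino on a carbonyl carbon changes the dose needed for half-maximal effect at all.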